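A few compounds are considered here, and "the series" means these few. Any claim that something is new, unique, unknown or untested is made for them only; others in the source may bear on it.

In a functional assay on HeLa cells (Homo sapiens) for antiproliferative activity, read by MTT assay, with a stated time of 48 h (on this read-out lower numbers stand for stronger inhibition and higher numbers for weaker inhibition), three compounds on a shared core have been measured: compound 1 (`CCOc1cc(-c2ccc3[nH]ccc3c2)cn2c(-c3cc(OC)c(OC)c(OC)c3)nnc12`) gives 166 nM while compound 2 (`COc1cc(-c2nnc3c(OC(C)C)cc(-c4ccc5[nH]ccc5c4)cn23)cc(OC)c1OC`) gives 261 nM and compound 3 (`COc1cc(-c2nnc3c(OC(C)C)cc(-c4ccc5c(ccn5C)c4)cn23)cc(OC)c1OC`) gives 503 nM as its number. Compound 3 therefore lies within the usual scatter of compound 2, while its number stands higher than that of compound 1 by more than that scatter.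

Compound 4 (`COc1cc(-c2nnc3c(OC4CC4)cc(-c4ccc5c(ccn5C)c4)cn23)cc(OC)c1OC`) has cyclopropyl in place of isopropyl on an oxygen on an aromatic ring and is otherwise the same as compound 3. Among the measured compounds shown here, no measured pair makes this exact swap. The nearest evidence is a change to the group on the same oxygen, methyl in place of hydrogen on a saturated chain carbon, which gave a 1.6-fold higher number from compound 1 to compound 2 (0.20 log units; within the scatter) and stayed small. The other step, methyl in place of hydrogen on an aromatic nitrogen, gave a 1.9-fold higher number from compound 2 to compound 3 (0.28 log units; within the scatter) and does not touch this oxygen.

Neither step went beyond the scatter, so no shift beyond the scatter is expected in this assay for this swap, in either direction. The estimated step is a 1.1-fold lower number from compound 3 to compound 4 (0.05 log units; within the scatter) and counts as no real change. For compound 4 the expected value is 450 nM within an estimated range of 200 nM to 1000 nM for repeated measurements.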

Compound 4, half-maximal inhibitory concentration: 97 nM
Compound 4: middle estimate off by 4.6-fold (0.67 log units), on the high side, outside the stated range (below it).
By their numbers in this assay, from the lowest: compounds 4, 1, 2 and 3 (each within the scatter of the next, the first and the last beyond it).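

In this assay, among the compounds shown here, the group on this oxygen matters more than the earlier compounds suggested: a 5.2-fold lower number from compound 3 to compound 4 (0.71 log units; beyond the scatter) lies beyond the scatter, whereas the only earlier change at this oxygen, a 1.6-fold higher number from compound 1 to compound 2 (0.20 log units; within the scatter), stayed within it. Isopropyl and cyclopropyl have the same count of heavy atoms, all of them carbon, and neither has a hydrogen-bond donor or acceptor, so the clear difference between them in the computed comparison is the three-membered ring of cyclopropyl, and this swap shows that a change leaving those counts untouched can still shift the number at this position. Nothing measured here explains why this swap has such an effect.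

The compounds shown leave open whether the same swap would give a similar step with hydrogen rather than methyl on the aromatic nitrogen, as in compound 2. They also leave open how other groups on this oxygen would behave, such as cyclobutyl, a longer chain or a chain ending in an amine.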